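The compounds below may be only part of what the source reports. "The series", "measured", "known", "first", "only" and "open" are said of these compounds alone.

Measured in a functional assay on C6 cells (Rattus norvegicus) for inhibition, read by sulforhodamine B assay, with a stated time of 72 h; a lower number here means that less compound is needed, a higher number that more compound is needed for the effect:
Compound 1 `O=C(/C=C/c1ccc([N+](=O)[O-])o1)c1ccc(I)cc1`: 2100 nM
Compound 2 `CSc1ccc(C(=O)/C=C/c2ccc([N+](=O)[O-])o2)cc1`: 1600 nM

Within the data shown here, compound 2 holds the lower of only two numbers, but compound 1 lies within the scatter of it, so the two cannot be ranked. Compound 3 `CCCCc1ccc(C(=O)/C=C/c2ccc([N+](=O)[O-])o2)cc1`, not yet measured in this assay, carries butyl in place of methylsulfanyl on an aromatic carbon. Among the measured compounds shown here, one measured step bears on this change, the swap at the same aromatic carbon: a 1.3-fold lower number from compound 1 to compound 2 (0.12 log units; within the scatter). For the measured compounds named here, that step stayed within the scatter, yet it is a single step, and no compound with butyl has been measured. A step beyond the scatter is therefore not expected, and no direction can be favoured. The expected change is a 1.1-fold higher number from compound 2 to compound 3 (0.05 log units; within the scatter). For compound 3 the estimate is 1800 nM, with an expected range of 800 nM to 4000 nM.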

Compound 3, half-maximal effective concentration: 1700 nM
The estimate for compound 3 lay 1.1-fold (0.02 log units) above the measured number, within the range that was stated.
By their numbers in this assay, from the lowest: compounds 2, 3 and 1 (each within the scatter of the next).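

In this assay, butyl on this aromatic carbon, para to a large group, gives a 1.1-fold higher number from compound 2 to compound 3 (0.03 log units; within the scatter) when it replaces methylsulfanyl, and a 1.2-fold lower number from compound 1 to compound 3 (0.09 log units; within the scatter) when it replaces iodo. Butyl is made of carbon only and has no hydrogen-bond acceptor, whereas methylsulfanyl has a sulfur and a hydrogen-bond acceptor, yet the step between them stays within the scatter, so iodo, methylsulfanyl and butyl cannot be told apart at this position. Nothing available bears on the reason for this result.

The compounds shown leave open whether an amine, a carboxylic acid or a chain longer than butyl at this place would move the number beyond the scatter. They also leave open whether the same would hold if the shared core were changed elsewhere.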